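The source may report more compounds than this note shows. Statements on the series, on what has been measured and on what is new or still open speak of the compounds shown alone.

The series shares one core, carried by compound 2 `CCSCCn1c(N2CCN(C)CC2)nc2ccccc21`, which differs from compound 1 `CCCCOCCn1c(N2CCCN(C)CC2)nc2ccccc21` and compound 3 `CCOCCn1c(N2CCCN(Cc3ccccc3)CC2)nc2ccccc21` in the chain on the aromatic nitrogen and in the saturated ring attached to the core. All three have been tested in a functional assay on ileum for inhibition of histamine H1 receptor (Cavia porcellus); a lower number here means a stronger inhibitor, a higher number a weaker inhibitor. Compound 1 gives 10 nM, compound 3 gives 15 nM and compound 2 gives 19 nM. Compound 2 thus has the highest of the three numbers, but the gaps to compound 3 and to compound 1 both fall within the usual scatter, so the three compounds read as indistinguishable in this assay.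

Compound 4 `CCCn1c(N2CCN(C)CC2)nc2ccccc21` is the next one, and it relates to compound 2 by a single change: methyl in place of ethylsulfanyl on a saturated chain carbon, two bonds along the chain from an aromatic nitrogen. For the measured compounds named here, nothing in the measured set isolates this change, since no pair of measured compounds differs in just one place. Only the trend that the chains in compound 1 and compound 3 are longer than that in compound 4 offers any hint.

On that basis compound 4 is expected to be somewhat weaker, with the step of a 2.1-fold higher number from compound 2 to compound 4 (0.32 log units; beyond the scatter) estimated to sit at or slightly beyond the scatter. Compound 4 is estimated at 40 nM, in a range from 10 nM to 150 nM.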

Compound 4, half-maximal inhibitory concentration: 380 nM
For compound 4 the middle estimate is 9.5-fold (0.98 log units) below the measured one, and the stated range ends below it.
By their numbers in this assay, from the lowest: compounds 1, 3 and 2 (each within the scatter of the next); then compound 4.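

In this assay, for the compounds shown here, the single change from ethylsulfanyl to methyl on a saturated chain carbon, two bonds along the chain from an aromatic nitrogen, is a large one: a 20-fold higher number from compound 2 to compound 4 (1.30 log units; beyond the scatter). Compounds 1, 2 and 3 differ from one another in more than one place, so they could not show how much this position counts on its own; this step shows that, with the rest of compound 2 held constant, going from 2-(ethylsulfanyl)ethyl to propyl costs far more than the scatter. Nothing at hand accounts for the size of this step.

The change removes the sulfur and shortens the chain at once, so the compounds shown leave open which of the two carries the step; a pentyl chain at this place on the core of compound 2 would keep the length without the sulfur. Also open, on these data alone, is whether a step of this size would recur with the saturated ring and its substituents as they stand in compound 1 and compound 3.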